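The source may report more compounds than this note shows. Statements on the series, on what has been measured and on what is new or still open speak of the compounds shown alone.

Working notes on the series

Two cores appear here. Compound 1 `COc1cccc(/C=C/C(=O)C(=Cc2ccc(O)c(F)c2)C(=O)/C=C/c2cccc(OC)c2OC)c1OC` and compound 2 `COc1cc(C=C(C(=O)/C=C/c2cccc(OC)c2OC)C(=O)/C=C/c2cccc(OC)c2OC)cc(Br)c1O` share one core; compound 3 `COc1cc(OC)c(/C=C/C(=O)C(=Cc2ccc(O)c(F)c2)C(=O)/C=C/c2c(OC)cc(OC)cc2OC)c(OC)c1` and the unmeasured compound 4 `COc1cc(OC)c(/C=C/C(=O)C(=Cc2cc(Br)c(O)c(OC)c2)C(=O)/C=C/c2c(OC)cc(OC)cc2OC)c(OC)c1` share the other. How the core of compound 3 differs from the core of compound 1 is not broken down here.

In a functional assay on HepG2 cells (Homo sapiens) for antiproliferative activity, read by sulforhodamine B assay, with a stated time of 48 h (on this read-out higher numbers stand for weaker inhibition and lower numbers for stronger inhibition), compound 1 gives 220 nM, and compound 2 gives 240 nM. Among the measured compounds shown here, the step of a 1.1-fold higher number from compound 1 to compound 2 (0.04 log units; within the scatter) is the only measured step for the change (3-bromo-4-hydroxy-5-methoxyphenyl in place of 3-fluoro-4-hydroxyphenyl on a double-bonded chain carbon bound to a double-bonded chain carbon), and it lies within the scatter: the two values cannot be told apart.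

Compound 3 stands apart. In this assay compound 3 gives 810 nM, which is beyond the scatter from both compound 1 and compound 2, and no single counted change links compound 3 to either of them.

Compound 4 carries the change (3-bromo-4-hydroxy-5-methoxyphenyl in place of 3-fluoro-4-hydroxyphenyl on a double-bonded chain carbon bound to a double-bonded chain carbon). This is the same change as that from compound 1 to compound 2, at the same place, but now on the core of compound 3. For the measured compounds named here, only one earlier instance exists, so the expectation rests on that step alone. The step from compound 3 to compound 4 in this assay is expected to be a 1.1-fold higher number from compound 3 to compound 4 (0.05 log units; within the scatter), resting on the flat step a 1.1-fold higher number from compound 1 to compound 2 (0.04 log units; within the scatter). For compound 4 the value in this assay is therefore estimated at 900 nM, with a range from 450 nM to 1800 nM, and the measurement will show whether the change behaves the same way on this core.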

Compound 4, half-maximal inhibitory concentration: 660 nM
For compound 4 the middle estimate is 1.4-fold (0.13 log units) above the measured one; the measured number falls inside the stated range.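

In this assay, placing 3-bromo-4-hydroxy-5-methoxyphenyl where 3-fluoro-4-hydroxyphenyl stood gives a 1.2-fold lower number from compound 3 to compound 4 (0.09 log units; within the scatter), so the change is flat on the core of compound 3 as well. Set beside the earlier step, the change shows no detectable dependence on which of these two cores carries it: the same change on two cores in this assay, a 1.1-fold higher number (0.04 log units; within the scatter) from compound 1 to compound 2 and a 1.2-fold lower number (0.09 log units; within the scatter) from compound 3 to compound 4, 1.3-fold (0.13 log units) apart, within the scatter of two such steps. Among the compounds shown here, this supports treating the exchange of these two aryl groups as neutral on both cores in this assay, but it rests on only two matched pairs, cannot exclude a small effect of either sign, and says nothing about whether any other change would carry across the cores.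

As far as these compounds go, all four compounds carry a halogen and a hydroxy group on the aryl ring at this place, so it remains open whether a phenyl ring bearing an amine or a carboxylic acid instead would also give the same step on both cores. The contribution of each part of the two cores also stays open, as no change at a single place within either core is shown.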